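A methylsulfonyl swap in a series at its limit

The compounds below may be only part of what the source reports. "The series", "measured", "known", "first", "only" and "open" are said of these compounds alone.

In a toxicity assay on NIH3T3 cells (Mus musculus) for cytotoxicity, read by resazurin assay (a lower number here means that less compound is needed, a higher number that more compound is needed for the effect), compound 3 (`Cc1ccccc1-c1ccc(Cn2cncc2CNc2ccc(-c3nc4ccccc4s3)c(-c3ccccc3)c2)cc1`) gives > 1000 nM as a limit of the assay, not a number. Compound 1 (`c1ccc(-c2ccc(Cn3cncc3CNc3ccc(-c4nc5ccccc5s4)c(-c4ccccc4)c3)cc2)cc1`) gives > 1000 nM as a limit too. Compound 2 (`Clc1ccc(Cn2cncc2CNc2ccc(-c3nc4ccccc4s3)c(-c3ccccc3)c2)cc1`) gives > 1000 nM as a limit as well. Compound 4 (`CS(=O)(=O)c1ccc(Cn2cncc2CNc2ccc(-c3nc4ccccc4s3)c(-c3ccccc3)c2)cc1`) is still unmeasured. It differs from compound 3 by one swap (methylsulfonyl in place of 2-methylphenyl on an aromatic carbon), methylsulfonyl in place of 2-methylphenyl on an aromatic carbon. Among the measured compounds shown here, three measured steps bear on this swap: a step that the two limits leave unreadable from compound 1 to compound 2 and a step that the two limits leave unreadable from compound 1 to compound 3 and a step that the two limits leave unreadable from compound 2 to compound 3 so none offers a size to carry over. All that can be read is the limit of > 1000 nM in this assay, at which 3 of the 3 values shown sit, and nothing more. The expected change is therefore a step that the limit leaves unreadable from compound 3 to compound 4 in this assay with no direction that can be supported. For compound 4 the estimate is 2000 nM with an expected range of 1000 nM to 6000 nM and another limit is the likeliest report.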

Compound 4, half-maximal effective concentration: > 1000 nM
Compound 4: only a limit was reported; the forecaster's own chance of this, stated with the estimate: 85%; the middle value is on the limit's open side.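

No step between compound 4 and compound 1, compound 2 or compound 3 can be read, because all four stand at the same limit: the limit of > 1000 nM in this assay, at which 4 of the 4 values shown sit.

Left open is whether the groups swapped among these compounds change the reading in this assay at all, and by how much.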